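Phenylurea-quinoline series: from ethyl to hydroxy on the aryl ring

The source may report more compounds than this note shows. Statements on the series, on what has been measured and on what is new or still open speak of the compounds shown alone.

Compound 1 `CCc1ccc(NC(=O)Nc2cc(C)nc3ccccc23)cc1`: 16000 nM
Compound 2 `COc1ccc(NC(=O)Nc2cc(C)nc3ccccc23)cc1F`: > 25000 nM
Compound 3 `Cc1cc(NC(=O)Nc2cc(Cl)cc(Cl)c2)c2ccccc2n1`: > 25000 nM

Three compounds sharing a urea-linked core were examined in an ADME assay on HEK293 cells (Homo sapiens) for cytotoxicity, with a stated time of 72 h; a higher number here means that more compound is needed for the effect, a lower number that less compound is needed. For the measured compounds named here, compound 1 gives 16000 nM, the only numerical value among the three. Compound 2 returns only a limit of the assay, > 25000 nM. Compound 3 likewise returns only a limit, > 25000 nM. Going by the values given here, compound 1 therefore stands as the sole compound with a number, while the other two sit at the limit (the limit of > 25000 nM in this assay, at which 2 of the 3 values shown sit).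

Compound 4 `Cc1cc(NC(=O)Nc2ccc(O)cc2)c2ccccc2n1` differs from compound 1 in one place: hydroxy in place of ethyl on an aromatic carbon. The change sits on an aromatic carbon of a six-membered aromatic ring of carbon only, para to a large group.

No step between two measured compounds is shown here, so the size of this step can only be expected. In this assay a small shift toward a higher number, or none beyond the scatter, is expected for compound 4, which is estimated at 22000 nM within 10000 nM to 50000 nM. The step from compound 1 to compound 4 this implies is expected to be a 1.4-fold higher number from compound 1 to compound 4 (0.14 log units; within the scatter).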

Compound 4, half-maximal effective concentration: > 25000 nM
Compound 4: no number, only a limit (the forecaster's own chance of this, stated with the estimate: 50%); at least 1.1-fold (0.05 log units) between middle value and limit.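

In this assay, for the compounds shown here, hydroxy in place of ethyl on an aromatic carbon, para to a large group, gives the first step that can be read in this set: an at least 1.5-fold higher number from compound 1 to compound 4 (0.19 log units; that floor lies within the scatter). From the compounds shown here alone, this step is only a floor and not a measured size, so the true distance between the two compounds remains unknown and could still lie within the scatter. The only compound with a number loses that number when ethyl gives way to hydroxy at this position, and compound 4 joins the other compounds at the limit: the limit of > 25000 nM in this assay, at which 3 of the 4 values shown sit.

The compounds shown leave open how far compound 4 actually lies from compound 1. They also leave open whether an amine or a longer chain such as propyl at this position would give a number or would also end at the limit.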